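Swapping Methoxy for Methyl on the Amide Side Chain

The source may hold more compounds than are shown below. What is called first, only, known or untested is meant among the compounds shown, and "the series" means these compounds.

Three measured compounds share one core and differ only in the group carried by the amide-type nitrogen. Compound 1 `Cc1ccc(OCC(=O)N(Cc2cccs2)c2cnn(C)c2)cc1` gives 63000 nM in an assay on HEK293 cells for agonist activity at transient receptor potential cation channel subfamily M member 8 (Homo sapiens), read by fluorescence and calcium flux, with a stated time of 15 min; on this read-out higher numbers stand for an effect only at larger amounts of compound and lower numbers for an effect already at smaller amounts. Compound 2 `Cc1ccc(OCC(=O)N(Cc2cccs2)c2ccnn2C)cc1` gives 422 nM in this assay, and compound 3 `COCCN(Cc1cccs1)C(=O)COc1ccc(C)cc1` gives 400 nM. Compound 3 has the lowest of the three numbers, but its gap to compound 2 is within the scatter: a 1.1-fold lower number from compound 2 to compound 3 (0.02 log units; within the scatter). The two large steps are a 150-fold lower number from compound 1 to compound 2 (2.17 log units; beyond the scatter) and a 160-fold lower number from compound 1 to compound 3 (2.20 log units; beyond the scatter).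

Compound 4 `CCCN(Cc1cccs1)C(=O)COc1ccc(C)cc1` has not yet been measured. It differs from compound 3 in this way: methyl in place of methoxy on a saturated chain carbon, two bonds along the chain from an amide-type nitrogen. Among the compounds with values here, no measured step alters the chain itself; the closest guide is a 1.1-fold lower number from compound 2 to compound 3 (0.02 log units; within the scatter), which shows that quite different groups on this nitrogen can give similar numbers. The step in this assay is therefore expected to be small, with no clear direction: a 1.1-fold higher number from compound 3 to compound 4 (0.05 log units; within the scatter). Compound 4 is expected to give 450 nM, in a range from 150 nM to 1500 nM.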

Compound 4, half-maximal effective concentration: 40 nM
Beside the measured number, compound 4's estimate is 11-fold (1.05 log units) above it, outside the stated range (below it).
By their numbers in this assay, from the lowest: compound 4; then compounds 3 and 2 (each within the scatter of the next); then compound 1.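

In this assay the chain on this nitrogen responds strongly to one small exchange, with a 10-fold lower number from compound 3 to compound 4 (1.00 log units; beyond the scatter) when methyl replaces methoxy on a saturated chain carbon, two bonds along the chain from an amide-type nitrogen. The match between compound 2 and compound 3 therefore did not mean that groups on this nitrogen are interchangeable, since 2-methoxyethyl and propyl clearly part ways here. Propyl also stands clear of both ring-bearing groups, giving an 11-fold lower number from compound 2 to compound 4 (1.02 log units; beyond the scatter) against 1-methyl-1H-pyrazol-5-yl and a 1600-fold lower number from compound 1 to compound 4 (3.20 log units; beyond the scatter) against 1-methyl-1H-pyrazol-4-yl.

The compounds shown leave open whether a longer chain such as butyl, a branched chain or a chain ending in an amine would move the number further in either direction. Nothing available explains why this exchange has so large an effect.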